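Cyclohexylthio in Place of Methylthio on the Shared Core

A few compounds are considered here, and "the series" means these few. Any claim that something is new, unique, unknown or untested is made for them only; others in the source may bear on it.

Compound 3 `CSc1ccc(NC2=NCCN2)cc1` carries a methyl on its sulfur. In an assay (Rattus norvegicus) for binding affinity to prostacyclin receptor (Homo sapiens), read by radioligand binding (on this read-out lower numbers stand for stronger inhibition and higher numbers for weaker inhibition), compound 3 gives only a limit, < 10000 nM, so no number stands for it. Compound 4 `c1cc(SC2CCCCC2)ccc1NC1=NCCN1` differs by cyclohexyl in place of methyl on a sulfur. For the measured compounds named here, two measured steps bear on this change. Compound 2 `c1ccc(Sc2ccc(NC3=NCCN3)cc2)cc1`, with phenyl on the sulfur, gives 794 nM in this assay, and the step that the limit leaves unreadable from compound 2 to compound 3 cannot be read in size. Compound 1 `Clc1ccc(Sc2ccc(NC3=NCCN3)cc2)cc1` gives 79.4 nM, and a 10-fold higher number from compound 1 to compound 2 (1.00 log units; beyond the scatter) shows how a single change on the outer ring shifts the number. Since a cyclohexyl again places a six-membered ring on the sulfur, compound 4 is expected to land between compound 2 and the limit of compound 3. The estimated step that the limit leaves unreadable from compound 3 to compound 4 is expected to run toward stronger binding. Compound 4 is estimated at 1500 nM, within 300 nM to 8000 nM.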

Compound 4, inhibition constant: 3160 nM
The estimate for compound 4 lay 2.1-fold (0.32 log units) below the measured number, within the range that was stated.
By their numbers in this assay, from the lowest: compound 1; then compound 2; then compound 4.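

With cyclohexyl on the sulfur, compound 4 gives a readable number for a non-aromatic ring at this position, and in this assay replacing phenyl shows a 4.0-fold higher number from compound 2 to compound 4 (0.60 log units; beyond the scatter). On this pair, the phenyl on the sulfur reads as the stronger of the two six-membered rings. The value of compound 3 remains a limit, and the steps that involve it cannot be read: the limit of < 10000 nM in this assay, at which 1 of the 4 values shown sits.

Going by these compounds, it remains open whether a chloro on the cyclohexyl ring would shift the number as the outer-ring change between compound 1 and compound 2 does. Also open, on these data alone, is how a longer chain or a benzyl on the sulfur would read in this assay.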